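Aryl swap on the triazole of the shared core

The source may hold more compounds than are shown below. What is called first, only, known or untested is meant among the compounds shown, and "the series" means these compounds.

Compound 3 `O=C1O/C(=C\Cn2cc(-c3ccc(Br)cc3)nn2)C(OCc2ccccc2)=C1OCc1ccccc1` is one of three measured members of the series. In an ADME assay on HFF cells (Homo sapiens) for cytotoxicity, read by MTT assay, with a stated time of 72 h (on this read-out lower numbers stand for stronger inhibition and higher numbers for weaker inhibition), compound 3 reaches only the limit of the assay, > 100000 nM. Compound 2 `Cc1ccc(-c2cn(C/C=C3\OC(=O)C(OCc4ccccc4)=C3OCc3ccccc3)nn2)cc1`, the methyl analogue, likewise gives a limit in this assay, > 100000 nM. The step that the two limits leave unreadable from compound 2 to compound 3 is therefore unreadable, as the limit of > 100000 nM in this assay, at which 2 of the 3 values shown sit, records. For the measured compounds named here, compound 1 `CC(C)(C)c1cn(C[C@H](O)[C@H]2OC(=O)C(OCc3ccccc3)=C2OCc2ccccc2)nn1`, which carries a tert-butyl group and a different link to the core, is the only member with a number, 13300 nM in this assay.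

Compound 4 `COc1ccccc1-c1cn(C/C=C2\OC(=O)C(OCc3ccccc3)=C2OCc2ccccc2)nn1` arises from compound 3 by 2-methoxyphenyl in place of 4-bromophenyl on an aromatic carbon. Going by the values given here, no measured step involves a 2-methoxyphenyl group, and the one aryl-to-aryl exchange at this position, between compound 2 and compound 3, shows nothing beyond two limits. The expectation for compound 4 is therefore that it stays near that limit, with the step of a number no higher from compound 3 to compound 4 (the limit leaves the size open) expected to be small or again unreadable. Compound 4 is estimated at 100000 nM in this assay, within 40000 nM to 300000 nM, most likely reported once more as a limit.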

Compound 4, half-maximal inhibitory concentration: > 100000 nM
Compound 4 gave a limit, no number; the forecaster's own chance of this, stated with the estimate: 70%; the middle value lies on the limit itself.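

In this assay, for the compounds shown here, compound 4 gives only a limit, > 100000 nM, so no step among compound 2, compound 3 and compound 4 can be read: the limit of > 100000 nM in this assay, at which 3 of the 4 values shown sit. The compounds shown leave open whether exchanging the aryl group at this position changes the read-out at all.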